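Working notes on the step from compound 3 to compound 4

The source may report more compounds than this note shows. Statements on the series, on what has been measured and on what is new or still open speak of the compounds shown alone.

Measured so far:
compound 1, `C=CCCCCCC#CC#CC(O)CC(C)=O`, 3.74 ug/mL
compound 2, `C=CCCCCCCCC#CC#CC(O)CC(C)=O`, 3.52 ug/mL
compound 3, `CCCCCCCC#CC#CCO`, 4.45 ug/mL

All three numbers come from a functional assay on SK-MEL-2 cells (Homo sapiens) for cytotoxicity; on this read-out lower numbers stand for an effect already at smaller amounts and higher numbers for an effect only at larger amounts of compound. Compound 3 has the highest of the three numbers, but its distance to compound 1 and to compound 2 is within the scatter, so no order among the three can be read from these values. Going by the values given here, the one measured step, a 1.1-fold lower number from compound 1 to compound 2 (0.03 log units; within the scatter), is also within the scatter.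

Compound 4, `CCCCCCCC#CC#CC(O)CC(C)=O`, has not yet been measured in this assay. It differs from compound 3 by 2-oxopropyl in place of hydrogen on a saturated chain carbon bound to an oxygen on a saturated carbon and a triple-bonded carbon. Among the compounds with values here, no measured step shows exactly this change; the nearest information is that compound 1 and compound 2, which both carry the 2-oxopropyl group, give numbers that sit within the scatter of the number for compound 3, which lacks it. On this basis no step beyond the scatter is expected from compound 3 to compound 4; the expected step is a 1.2-fold lower number from compound 3 to compound 4 (0.07 log units; within the scatter). Compound 4 is therefore estimated at 3.8 ug/mL, with a range from 2 ug/mL to 7.5 ug/mL.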

Compound 4, concentration for half-maximal effect: 1.4 ug/mL
For compound 4 the middle estimate is 2.7-fold (0.43 log units) above the measured one; the measured number lies below the stated range.
By their numbers in this assay, from the lowest: compound 4; then compounds 2, 1 and 3 (each within the scatter of the next).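

In this assay, going by these compounds alone, 2-oxopropyl in place of hydrogen on the saturated chain carbon bound to an oxygen on a saturated carbon and a triple-bonded carbon gives the first step that lies beyond the scatter (a 3.2-fold lower number from compound 3 to compound 4 (0.50 log units; beyond the scatter)). The far end of the chain also counts, as two steps with the 2-oxopropyl group kept in place show: ethyl in place of vinyl (a 2.7-fold lower number from compound 1 to compound 4 (0.43 log units; beyond the scatter)) and hydrogen in place of vinyl (a 2.5-fold lower number from compound 2 to compound 4 (0.40 log units; beyond the scatter)) both go to a lower number, and each is modest in size. No measured evidence bears on the cause of these steps, so they stand here as observations only.

The compounds shown leave open whether the lower number of compound 4 depends on the carbonyl of the 2-oxopropyl group, which a carboxylic acid or an amine at the same place would test. They also leave open how far the saturated end of the chain can be extended, as a longer saturated chain on the same core would show, and whether the 2-oxopropyl step holds there.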